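The source may report more compounds than this note shows. Statements on the series, on what has been measured and on what is new or still open speak of the compounds shown alone.

Measured so far in an ADME assay on PC-3 cells (Homo sapiens) for cytotoxicity, read by sulforhodamine B assay, with a stated time of 48 h, tested at 10 uM; a lower number here means less inhibition, a higher number more inhibition at the concentration tested (going by the name of the read-out):
compound 1 `CCCCc1cn(C(c2ccccc2)c2cc3cc(Br)ccc3nc2OC)nn1`: 5.54%
compound 2 `COc1nc2ccc(Br)cc2cc1C(c1ccccc1)n1cc(-c2cccc(F)c2)nn1`: 14.6%

Two compounds of the shared core have numbers in this assay. Compound 1 gives 5.54% and compound 2 gives 14.6%. Among the compounds with values here, the one measured step, a number 9.1 percentage points higher from compound 1 to compound 2 (within the scatter), stays within the scatter, so compound 2 holds the higher of the two numbers without being separable from compound 1.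

Compound 3 `COc1nc2ccc(Br)cc2cc1C(c1ccccc1)n1cc(-c2ccc(OC(F)(F)F)cc2)nn1` is the next member. It differs from compound 2 in one place: 4-(trifluoromethoxy)phenyl in place of 3-fluorophenyl on an aromatic carbon. Within the data shown here, no measured step bears directly on this change; the only step in hand, a number 9.1 percentage points higher from compound 1 to compound 2 (within the scatter), concerns butyl against 3-fluorophenyl on that aromatic carbon and did not move the number beyond the scatter. With a single within-scatter step as the whole record, a swap of one aryl group for another at the same place gives no ground to expect a move. The expected step is therefore a number 0.4 percentage points higher from compound 2 to compound 3 (within the scatter), nothing beyond the scatter. Compound 3 is estimated at 15%, within a range from 0% to 35%.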

Compound 3, a percentage reported as inhibition, at one concentration (the size of the read-out at that concentration, not a potency): 21.6%
Compound 3: middle estimate off by 6.6 percentage points, on the low side; low and high end bracket the measured number.
By their numbers in this assay, from the lowest: compounds 1, 2 and 3 (each within the scatter of the next, the first and the last beyond it).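

Within the data shown here, at the aromatic carbon of the five-membered aromatic ring with 3 nitrogen, this assay now gives the first separable step: a number 16.1 percentage points higher from compound 1 to compound 3 (beyond the scatter), with 4-(trifluoromethoxy)phenyl in place of butyl. The swap of one aryl group for another remains unresolved at a number 7 percentage points higher from compound 2 to compound 3 (within the scatter), so 3-fluorophenyl and 4-(trifluoromethoxy)phenyl cannot be told apart here, and because compound 2 lies within the scatter of both compound 1 and compound 3, the separation holds for one pair only and sets no general rule for aryl against alkyl groups at this position. No measurement of any property of these groups is available to account for the step.

The compounds shown leave open what an amine, a carboxylic acid or a chain longer than butyl would give on that aromatic carbon. They also leave open whether the step would persist with the bromine or the methoxy group of the shared core replaced, and, since each number comes from a single concentration, how these compounds compare in potency.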